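This account rests on a few compounds, and the source may have more. Where it says the series, first, only, none or still open, it means among the compounds named here.

Measured compounds in a functional assay on A549 cells (Homo sapiens) for inhibition, read by MTT assay, with a stated time of 72 h; on this read-out lower numbers stand for stronger inhibition and higher numbers for weaker inhibition:
Compound 2 `CCN1C(=O)N(CC)C2C1NC(=S)N2/N=C/C=C/c1ccccc1OC` gives 610 nM.
Compound 1 `CCN1C(=O)N(CC)C2C1NC(=S)N2/N=C/C=C/c1ccccc1[N+](=O)[O-]` gives only a limit of this assay, > 100000 nM.

Compound 2 thus holds the only number shown; the one other value is a limit, at the limit of > 100000 nM in this assay, at which 1 of the 2 values shown sits. Among the measured compounds shown here, the single measured step, an at least 160-fold lower number from compound 1 to compound 2 (2.21 log units; beyond the scatter), concerns the aromatic carbon and not the place where compound 3 `CCN1C(=O)N(c2ccccc2)C2NC(=S)N(/N=C/C=C/c3ccccc3OC)C21` differs: phenyl in place of ethyl on an amide-type nitrogen in a ring. For the measured compounds named here, no measured step bears on this change, so no step beyond the scatter is expected in this assay. Compound 3 is therefore estimated at 600 nM, within 150 nM to 2500 nM, an expected step of a 1.0-fold lower number from compound 2 to compound 3 (0.01 log units; within the scatter).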

Compound 3, half-maximal inhibitory concentration: > 100000 nM
Compound 3: no number, only a limit (the forecaster's own chance of this, stated with the estimate: 10%); middle value at least 160-fold (2.22 log units) away from the limit.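

In this assay, the amide-type nitrogen in the ring proves sensitive to its substituent: phenyl in place of ethyl gives an at least 160-fold higher number from compound 2 to compound 3 (2.21 log units; beyond the scatter). Among the compounds shown here, the earlier compounds showed a large step only at the aromatic carbon, so this is the first sign that this second place on the core matters as well. Compound 3 gives a limit and not a number: the limit of > 100000 nM in this assay, at which 2 of the 3 values shown sit.

On these data alone, whether a propyl, cyclohexyl or benzyl group on this nitrogen would stay close to compound 2 or fall to the limit remains open. So does whether a methyl group would differ from ethyl here.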